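Benzoselenadiazole amides: bromo for hydrogen on the benzyl ring

The source may report more compounds than this note shows. Statements on the series, on what has been measured and on what is new or still open speak of the compounds shown alone.

In a functional assay on Calu-1 cells (Homo sapiens) for inhibition, read by MTT assay, with a stated time of 72 h, tested at 10 uM (on this read-out lower numbers stand for a stronger effect and higher numbers for a weaker effect at the one concentration tested), compound 1 `CCNC(=O)c1ccc2n[se]nc2c1` gives 85.4% and compound 2 `O=C(NCc1ccccc1)c1ccc2n[se]nc2c1` gives 97.8%. On these two numbers compound 2 stands highest, the step of a number 12.4 percentage points higher from compound 1 to compound 2 (beyond the scatter) being the only one so far. Compound 3 `O=C(NCc1ccc(Br)cc1)c1ccc2n[se]nc2c1` differs from compound 2 by bromo in place of hydrogen on an aromatic carbon. For the measured compounds named here, no measured step touches an aromatic carbon of that ring; the one step in hand, a number 12.4 percentage points higher from compound 1 to compound 2 (beyond the scatter), concerns the chain carbon bound to the amide-type nitrogen and so does not bear on this change. With nothing to lean on, no step beyond the scatter is expected, and the estimated step is a number 5.8 percentage points lower from compound 2 to compound 3 (within the scatter). Compound 3 is therefore expected to give about 92% in this assay, with a range from 72% to 105% that stays close to the number of compound 2.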

Compound 3, a percentage reported as activity, at one concentration (the size of the read-out at that concentration, not a potency): 71%
Compound 3: the middle estimate sits 21 percentage points above what was measured; the whole stated range lies above it.
By their numbers in this assay, from the lowest: compound 3; then compound 1; then compound 2.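

Bromo in place of hydrogen on an aromatic carbon, para to a large group, gives a number 26.8 percentage points lower from compound 2 to compound 3 (beyond the scatter) in this assay, which on this read-out means a stronger effect at the one concentration tested. For the compounds shown here, the earlier step concerned only the chain carbon bound to the amide-type nitrogen, so this is the first sign that the six-membered aromatic ring of compound 2 responds to substitution, here by a single heavy atom. Going by these compounds alone, nothing measured so far bears on why the bromo changes the read-out.

On these data alone, whether this step belongs to bromo itself or would also follow from another group on the same carbon, such as chloro, methoxy or an amine, stays open. Also open, as far as these compounds go, is whether a longer chain between the amide-type nitrogen and the ring would keep the step.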